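Changing the aryl amide of compound 3

The source may hold more compounds than are shown below. What is called first, only, known or untested is meant among the compounds shown, and "the series" means these compounds.

Measured compounds and their results in an assay for inhibition of very long chain fatty acid elongase 6 (Homo sapiens); a lower number here means a stronger inhibitor, a higher number a weaker inhibitor:
Compound 1, `CCC1(COC(=O)Nc2ccc(F)cc2)OC(=O)Nc2ccc(Cl)cc21`, gives 2260 nM.
Compound 2, `O=C(Nc1ccc(F)cc1)OCC1(c2ccccc2)OC(=O)Nc2ccc(Cl)cc21`, sits at the assay limit of > 10000 nM.
Compound 3, `O=C1Nc2ccc(Cl)cc2C(CNC(=O)c2ccccc2F)(C(F)(F)F)O1`, gives 539 nM.

Compound 3 holds the lowest of the two numbers; compound 1 is its nearest neighbour with a higher number, a gap beyond the scatter, while compound 2 rests at the limit of > 10000 nM in this assay, at which 1 of the 3 values shown sits. Compound 4, `O=C1Nc2ccc(Cl)cc2C(CNC(=O)c2ccc(C(F)(F)F)cc2)(C(F)(F)F)O1`, differs from compound 3 by 4-(trifluoromethyl)phenyl in place of 2-fluorophenyl on a carbonyl carbon. Going by the values given here, the single measured step, an at least 4.4-fold higher number from compound 1 to compound 2 (0.64 log units; beyond the scatter), concerns a different place and does not bear on this change. No step beyond the scatter is therefore expected in this assay, so a 1.5-fold higher number from compound 3 to compound 4 (0.17 log units; within the scatter) is the expected outcome. Compound 4 is estimated at 800 nM, within 250 nM to 3000 nM.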

Compound 4, half-maximal inhibitory concentration: 813 nM
Compound 4: the middle estimate sits 1.0-fold (0.01 log units) below what was measured, and the stated range covers the measured number.
By their numbers in this assay, from the lowest: compounds 3 and 4 (each within the scatter of the next); then compound 1. At a limit, above all of these: compound 2.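

In this assay, going by these compounds alone, 4-(trifluoromethyl)phenyl in place of 2-fluorophenyl on the carbonyl carbon gives a 1.5-fold higher number from compound 3 to compound 4 (0.18 log units; within the scatter) and so gives a first reading at this position, which the earlier compounds did not vary. The two groups, which share one six-membered aromatic ring of carbon only, thus cannot be told apart here, although they differ in heavy atoms and in fluorine count. No measurement shown bears on the reason for this result.

From the compounds shown here alone, what an amine or a carboxylic acid on that ring would give remains open, as does replacing the ring with a longer alkyl chain.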